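This account rests on a few compounds, and the source may have more. Where it says the series, first, only, none or still open, it means among the compounds named here.

Measured in a functional assay on A549 cells (Homo sapiens) for inhibition, read by sulforhodamine B assay, with a stated time of 48 h, tested at 50 uM; on this read-out higher numbers stand for more inhibition of growth at the one concentration tested and lower numbers for less inhibition of growth:
- compound 1 `COc1ccc([C@@H]2C/C(=N/OCc3cn(-c4ccc(C#N)cc4)nn3)c3cc(CC=C(C)C)c(OC)cc3O2)cc1`: 42%
- compound 2 `COc1ccc([C@@H]2C/C(=N/OCc3cn(-c4ccc(C(N)=O)cc4)nn3)c3cc(CC=C(C)C)c(OC)cc3O2)cc1`: 100%

Of these two, compound 2 stands highest at 100%. Compound 3 `COc1ccc([C@@H]2C/C(=N/OCc3cn(-c4ccc(NC(=O)c5ccccc5)cc4)nn3)c3cc(CC=C(C)C)c(OC)cc3O2)cc1` differs from it by one change, (benzamido in place of carbamoyl on an aromatic carbon), with benzamido in place of carbamoyl on an aromatic carbon, para to a large group. Among the measured compounds shown here, one measured step bears on this. The step of a number 58 percentage points higher from compound 1 to compound 2 (beyond the scatter) brought in the carbamoyl that now leaves, and it was large and beyond the scatter. The read-out can therefore move strongly with the group at this carbon. For the measured compounds named here, no benzamido analogue has been measured, so the size remains uncertain, but compound 2 leaves little room upward and a fall is more likely. The expected step is a number 35 percentage points lower from compound 2 to compound 3 (beyond the scatter), smaller than the measured one. The estimate for compound 3 is 65%, with an expected range from 35% to 100%.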

Compound 3, percent growth inhibition at one concentration: 31%
The estimate for compound 3 lay 34 percentage points above the measured number, and the stated range ends above it.
By their numbers in this assay, from the lowest: compound 3; then compound 1; then compound 2.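

In this assay, benzamido in place of carbamoyl gave a number 69 percentage points lower from compound 2 to compound 3 (beyond the scatter), so the high reading of compound 2 does not carry over to this larger group, although both groups have the same count of hydrogen-bond donors and acceptors. Benzamido in place of the cyano group gave a number 11 percentage points lower from compound 1 to compound 3 (beyond the scatter), a modest step, which leaves carbamoyl as the only one of the three groups at this aromatic carbon with a high reading. Nothing available explains why the reading changes so strongly with the group at this carbon.

The compounds shown leave open whether an acetamido group, an amine or a carboxylic acid at this carbon would read nearer compound 2 or compound 3. They also leave open how a carbamoylmethyl group, with its longer chain, would read here.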